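The source may hold more compounds than are shown below. What is called first, only, known or untested is meant among the compounds shown, and "the series" means these compounds.

Measured compounds:

compound 1, `COc1ccccc1N1CCN(CCn2c(=O)[nH]c3cc[nH]c3c2=O)CC1`: in an assay for binding affinity to Adrenergic receptor alpha-1 (Rattus norvegicus) (a lower number here means a stronger inhibitor, a higher number a weaker inhibitor), compound 1 gives 2.31 nM
compound 2, `O=c1[nH]c2cc[nH]c2c(=O)n1CCN1CCN(c2ccccc2Cl)CC1`: in this assay compound 2 gives 0.94 nM
compound 3, `COc1ccccc1N1CCN(CCCn2c(=O)[nH]c3cc[nH]c3c2=O)CC1`: in this assay compound 3 gives 28 nM

Compound 3 stands highest of the three numbers in this assay, both compound 1 and compound 2 lying clearly lower, beyond the scatter.

Compound 4, `O=c1[nH]c2cc[nH]c2c(=O)n1CCCN1CCN(c2ccccc2Cl)CC1`, differs from compound 3 in one place: chloro in place of methoxy on an aromatic carbon. For the measured compounds named here, the only measured step that bears on this is the same exchange on the shorter-chain pair, a 2.5-fold lower number from compound 1 to compound 2 (0.39 log units; beyond the scatter). Going by the values given here, a step of similar size and direction is therefore expected, a 2.5-fold lower number from compound 3 to compound 4 (0.41 log units; beyond the scatter), given that only one such comparison exists. Compound 4 is estimated at 11 nM in this assay, with a range of 5 nM to 25 nM.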

Compound 4, inhibition constant: 59.8 nM
Compound 4: the middle estimate sits 5.4-fold (0.74 log units) below what was measured; the measured number lies above the stated range.
By their numbers in this assay, from the lowest: compound 2; then compound 1; then compound 3; then compound 4.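

Chloro in place of methoxy on this aromatic carbon keeps no single direction in this assay across the two cores: the longer-chain core gives a 2.1-fold higher number from compound 3 to compound 4 (0.33 log units; beyond the scatter) and so runs opposite to the shorter-chain pair. The outcome of this exchange therefore depends on the core that carries it, with the two steps lying clearly apart: the same change on two cores in this assay, a 2.5-fold lower number (0.39 log units; beyond the scatter) from compound 1 to compound 2 and a 2.1-fold higher number (0.33 log units; beyond the scatter) from compound 3 to compound 4, 5.2-fold (0.72 log units) apart, beyond the scatter of two such steps.

From the compounds shown here alone, it remains open whether a still longer chain would keep the direction seen with compound 3 and compound 4. Also open, going by these compounds, is how fluoro or methyl at this place would compare with chloro and methoxy on either core.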